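A 2,4-dichlorophenyl in place of 2,6-dichlorophenyl

A few compounds are considered here, and "the series" means these few. Any claim that something is new, unique, unknown or untested is made for them only; others in the source may bear on it.

Among the compounds with values here, in a functional assay on MDA-MB-231 cells (Homo sapiens) for antiproliferative activity, read by MTT assay, with a stated time of 24 h (a lower number here means a stronger inhibitor, a higher number a weaker inhibitor), compound 1 `O=C(O)CC(NC(=O)c1cccc(Br)c1)c1ccc(Cl)cc1Cl` gives 82500 nM and is the only compound so far with a numerical reading. In this assay compound 2 `O=C(O)CC(NC(=O)c1c(Cl)cccc1Cl)c1ccc(Cl)cc1Cl` reads > 100000 nM and this is a limit of the assay, not a number. Compound 2 therefore stands at the limit of > 100000 nM in this assay, at which 1 of the 2 values shown sits, and no closer position can be given for it. Within the data shown here, the one measured step is an at least 1.2-fold higher number from compound 1 to compound 2 (0.08 log units; that floor lies within the scatter) and it came with 2,6-dichlorophenyl in place of 3-bromophenyl on a carbonyl carbon. That step does not separate the two compounds beyond the scatter.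

Compound 3 `O=C(O)CC(NC(=O)c1ccc(Cl)cc1Cl)c1ccc(Cl)cc1Cl` differs from compound 2 by 2,4-dichlorophenyl in place of 2,6-dichlorophenyl on a carbonyl carbon and so carries 2,4-dichlorophenyl in place of 2,6-dichlorophenyl on a carbonyl carbon. Among the measured compounds shown here, no measured step tests this exchange directly. Compound 1 at 82500 nM is the nearest number available, so no step beyond the scatter is expected in this assay in either direction. The expected step is an at least 1.1-fold lower number from compound 2 to compound 3 (0.07 log units; that floor lies within the scatter) by this estimate. Compound 3 is estimated at 85000 nM with an expected range from 45000 nM to 140000 nM. A limit rather than a number remains possible for compound 3.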

Compound 3, half-maximal inhibitory concentration: 49200 nM
For compound 3 the middle estimate is 1.7-fold (0.24 log units) above the measured one; measured number inside the range.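

Exchanging 2,6-dichlorophenyl for 2,4-dichlorophenyl on a carbonyl carbon keeps the same atoms, joined differently, and in this assay it gives an at least 2.0-fold lower number from compound 2 to compound 3 (0.30 log units; that floor lies within the scatter); a numerical reading thus takes the place of a limit, though the step as printed does not pass the scatter. Compound 2 holds only a limit of the assay and not a number, so the true size of that step stays unknown: the limit of > 100000 nM in this assay, at which 1 of the 3 values shown sits.

The exchange of 3-bromophenyl for 2,4-dichlorophenyl on the same carbonyl carbon gives a 1.7-fold lower number from compound 1 to compound 3 (0.22 log units; within the scatter), so these two groups cannot be put in any order here, and the two compounds with numerical readings sit together within the scatter.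

The compounds shown leave open whether any group on this carbonyl carbon can move the reading clearly beyond the scatter from compound 1 and compound 3, for instance an unsubstituted phenyl, a methoxyphenyl or a pyridine ring. They also leave open whether the exchange at this place would read the same with a different group in place of the 2,4-dichlorophenyl on the other side of the amide, such as a 4-methoxyphenyl.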